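This account rests on a few compounds, and the source may have more. Where it says the series, first, only, none or still open, it means among the compounds named here.

Three compounds built on one shared core differ only in the group carried on a six-membered aromatic ring of carbon only. Compound 1 `Cc1nn(C)c2c1C(c1cccc(C(F)(F)F)c1)=NCCN2` bears a trifluoromethyl there, compound 2 `Cc1cccc(C2=NCCNc3c2c(C)nn3C)c1` a methyl, and compound 3 `Cc1nn(C)c2c1C(c1cccc([N+](=O)[O-])c1)=NCCN2` a nitro. In a functional assay on the whole organism for positive allosteric modulation, with Rattus norvegicus as the target (a higher number here means that more compound is needed for the effect, a lower number that less compound is needed), compound 1 gives 0.63 mg/kg, compound 2 gives 2.5 mg/kg and compound 3 gives 5 mg/kg. Exchanging the trifluoromethyl brings a 4.0-fold higher number from compound 1 to compound 2 (0.60 log units; beyond the scatter) and a 7.9-fold higher number from compound 1 to compound 3 (0.90 log units; beyond the scatter), so compound 3 stands furthest from compound 1 of the three; between compound 2 and compound 3 the step is a 2.0-fold higher number from compound 2 to compound 3 (0.30 log units; within the scatter), which lies within the scatter.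

Compound 4 `Cc1nn(C)c2c1C(c1cccc(N)c1)=NCCN2` has not yet been measured. Its change from compound 3 is amino in place of nitro on an aromatic carbon. The measured steps show that the group at this position can move the number modestly, yet none of them involves an amino group, so the direction for compound 4 cannot be read from them with confidence. A step of about a 1.3-fold lower number from compound 3 to compound 4 (0.10 log units; within the scatter) in this assay is expected, which means a change hardly beyond the scatter. Compound 4 is therefore estimated at 4 mg/kg in this assay, with a range from 1.3 mg/kg to 12 mg/kg.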

Compound 4, minimum effective dose: 2.5 mg/kg
The estimate for compound 4 lay 1.6-fold (0.20 log units) above the measured number, and the stated range covers the measured number.
By their numbers in this assay, from the lowest: compound 1; then compounds 2, 4 and 3 (each within the scatter of the next).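

In this assay the exchange of nitro for amino, which brings a hydrogen-bond donor where nitro had none, gives a 2.0-fold lower number from compound 3 to compound 4 (0.30 log units; within the scatter) and so adds a quite different group at this position without a step beyond the scatter. Amino and methyl also cannot be told apart here, with no change at the digits printed from compound 2 to compound 4 (within the scatter) as their comparison, while trifluoromethyl stays clear of amino, with a 4.0-fold higher number from compound 1 to compound 4 (0.60 log units; beyond the scatter) as the step, so compound 1 remains the only compound whose number lies beyond the scatter of every other compound shown. No measurement available here gives a reason for this pattern of numbers.

What the compounds shown leave open is whether trifluoromethyl is unusual at this position or whether other groups, such as a chlorine, a nitrile or a methoxy group, could match its low dose. They also leave open how much the place on the ring matters, since every group shown sits meta to a large group, and the same amino or trifluoromethyl elsewhere on the ring might give quite different numbers.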